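A Hexyl Gives Way to 3-Chlorophenyl

This account rests on a few compounds, and the source may have more. Where it says the series, first, only, none or still open, it means among the compounds named here.

In a functional assay on RAW264.7 cells (Mus musculus) for inhibition, read by Griess assay, with a stated time of 20 h (on this read-out higher numbers stand for weaker inhibition and lower numbers for stronger inhibition), compound 3 (`CCCCCCc1cn(-c2ccc(O)c(C(=O)N3CCCCC3)c2)nn1`) reads > 20000 nM, which is a limit and not a number. Compound 2 (`CC(C)CCc1cn(-c2ccc(O)c(C(=O)N3CCCCC3)c2)nn1`) reads > 20000 nM, also a limit. Compound 1 (`CCCNC(=O)c1cc(-n2cc(-c3cccc(Cl)c3)nn2)ccc1O`) reads > 20000 nM, again a limit. Compound 3 therefore has no number of its own and stands with the other two compounds: the limit of > 20000 nM in this assay, at which 3 of the 3 values shown sit.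

Compound 4 (`O=C(c1cc(-n2cc(-c3cccc(Cl)c3)nn2)ccc1O)N1CCCCC1`) keeps the core of compound 3 but carries 3-chlorophenyl in place of hexyl on an aromatic carbon of a five-membered aromatic ring with 3 nitrogen: 3-chlorophenyl in place of hexyl on an aromatic carbon.

Among the measured compounds shown here, the only measured step, a step that the two limits leave unreadable from compound 2 to compound 3, has no readable size and so offers nothing to carry over. The nearest guide is compound 1, which also carries the 3-chlorophenyl and reads > 20000 nM, only a limit. No step beyond the scatter is therefore expected in this assay, and the data suggest no direction for one. The expected step is a number no higher from compound 3 to compound 4 (the limit leaves the size open). A report of compound 4 as a limit is the more likely outcome. The estimated value for compound 4 is 20000 nM, expected to fall between 8000 nM and 40000 nM.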

Compound 4, half-maximal inhibitory concentration: > 20000 nM
Compound 4 gave a limit, no number (the forecaster's own chance of this, stated with the estimate: 65%); the middle value lies on the limit itself.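

The reading of compound 4 is > 20000 nM and that is a limit, not a number. Its steps from compound 1, compound 2 and compound 3 therefore cannot be read, and all four compounds stand together: the limit of > 20000 nM in this assay, at which 4 of the 4 values shown sit. The compounds shown leave open whether 3-chlorophenyl in place of hexyl, or piperidin-1-yl in place of propylamino, changes inhibition at all.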